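The compounds below may be only part of what the source reports. "The series", "measured", "known", "first", "only" and "open" are said of these compounds alone.

Compound 1 `O=C1[C@@H](NS(=O)(=O)c2cc3ncccc3s2)CCN1Cc1cc2c[nH]ccc-2n1` and compound 2 `O=C1[C@@H](NS(=O)(=O)c2cc3ccc(Cl)nc3s2)CCN1Cc1cc2c[nH]ccc-2n1` share one core and differ only in the group on the sulfonyl sulfur. In an assay on isolated protein for inhibition of coagulation factor X (Oryctolagus cuniculus), tested at 1 uM (a higher number here means more inhibition at the concentration tested (going by the name of the read-out), a lower number less inhibition), compound 1 gives 61%, and compound 2 gives 51%. For the measured compounds named here, the step of a number 10 percentage points lower from compound 1 to compound 2 (within the scatter) is the only measured step. Compound 2 therefore holds the lowest of the two numbers shown, but its gap to compound 1 is within the scatter, so no order between the two can be read.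

Compound 3 `CC(C)(C)c1ccc(S(=O)(=O)N[C@H]2CCN(Cc3cc4c[nH]ccc-4n3)C2=O)cc1` is the next member. Its change from compound 2 is a group of 10 heavy atoms (10 carbon; one six-membered aromatic ring of carbon only) in place of a group of 10 heavy atoms (7 carbon, 1 nitrogen, 1 sulfur, 1 chlorine; one five-membered aromatic ring with 1 hetero atom, one six-membered aromatic ring with 1 hetero atom), on a sulfonyl sulfur. The measured step from compound 1 to compound 2 sits at the same sulfonyl sulfur, yet it exchanges one bicyclic heteroaromatic group for another, whereas the present change puts a carbon-only six-membered ring there. Going by the values given here, no measured step covers that kind of exchange, and the one measured step at this place was within the scatter. On this basis no direction can be derived and the expectation for compound 3 is wide: compound 3 is estimated at 45% in this assay, with a range from 10% to 75%. The estimated step of a number 6 percentage points lower from compound 2 to compound 3 (within the scatter) is thus expected to fall within the scatter, with the range allowing a real drop or gain either way.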

Compound 3, a percentage reported as inhibition, at one concentration (the size of the read-out at that concentration, not a potency): 14%
Beside the measured number, compound 3's estimate is 31 percentage points above it; the measured number falls inside the stated range.
By their numbers in this assay, from the lowest: compound 3; then compounds 2 and 1 (each within the scatter of the next).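

For the compounds shown here, the change to 4-(tert-butyl)phenyl on the sulfonyl sulfur gives a number 37 percentage points lower from compound 2 to compound 3 (beyond the scatter) and a number 47 percentage points lower from compound 1 to compound 3 (beyond the scatter) in this assay, the first steps at this position to lie beyond the scatter. The position is therefore not indifferent to the group it carries: the two groups holding one five-membered and one six-membered aromatic ring stay within the scatter of each other, while the carbon-only six-membered ring stands well apart from both, and the entering group counts 0 hydrogen-bond acceptors against 2 in the group leaving compound 2. Nothing measured on these compounds explains the loss, so neither the ring type nor the acceptor count can be given as its cause.

Going by these compounds alone, the single step changes the ring system and adds the tert-butyl group together, so it remains open which of these goes with the lower number. A plain phenyl group would separate the tert-butyl group from the carbon-only ring, and a single pyridyl or thienyl ring on the sulfonyl sulfur would separate the hetero atom from the second ring.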